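The compounds below may be only part of what the source reports. "The series", "measured", "known", "first", "only" and "open" are said of these compounds alone.

Measured so far in a functional assay on A549 cells (Homo sapiens) for antiproliferative activity, read by MTT assay, with a stated time of 48 h; on this read-out lower numbers stand for stronger inhibition and higher numbers for weaker inhibition:
- compound 1 `COc1ccc(N(C)c2ccnc(Cl)n2)cc1O` gives 381 nM
- compound 2 `COc1ccc(N(C)c2ccnc(Cl)n2)cc1OCCC[Se]C#N` gives 3710 nM
- compound 3 `COc1ccc(N(C)c2cc(C)nc(C)n2)cc1` gives 277 nM

Compound 3 at 277 nM lies within the scatter of compound 1 at 381 nM and compound 2 at 3710 nM lies well clear of that scatter on the high side. Compound 4 `COc1ccc(N(C)c2cc(C)nc(C)n2)cc1[N+](=O)[O-]` differs from compound 3 by nitro in place of hydrogen on an aromatic carbon with nitro in place of hydrogen on an aromatic carbon, ortho to a methoxy group. Among the compounds with values here, the only measured step, a 9.7-fold higher number from compound 1 to compound 2 (0.99 log units; beyond the scatter), involves a different change, on an oxygen on an aromatic ring, so it offers only a weak upward lean. The expected step, a 1.6-fold higher number from compound 3 to compound 4 (0.21 log units; within the scatter), is therefore small and not clearly beyond the scatter. In this assay compound 4 is estimated at 450 nM with a range from 120 nM to 1700 nM expected.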

Compound 4, half-maximal inhibitory concentration: 3270 nM
The estimate for compound 4 lay 7.3-fold (0.86 log units) below the measured number, and the stated range ends below it.
By their numbers in this assay, from the lowest: compounds 3 and 1 (each within the scatter of the next); then compounds 4 and 2 (each within the scatter of the next).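

In this assay the step of a 12-fold higher number from compound 3 to compound 4 (1.07 log units; beyond the scatter) shows that the aromatic carbon ortho to a methoxy group is sensitive to substitution in this series. The earlier step concerned only a chain on an oxygen on an aromatic ring, whereas here nitro in place of hydrogen, directly on the ring carbon, is enough to produce a large change. Nothing available explains this step. On these data alone, whether an amine or a carboxylic acid at this same place would give a step of similar size remains open.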